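Decyl thioether in place of the dichlorophenyl amide

The source may hold more compounds than are shown below. What is called first, only, known or untested is meant among the compounds shown, and "the series" means these compounds.

Going by the values given here, compound 1 `Cn1c(Cc2nn(C)c(=O)c3ccccc23)nnc1SCCCC(=O)Nc1ccc(Cl)cc1Cl` is the one member of this series with a number: in an assay on isolated protein (Mus musculus) for inhibition of IL15-IL15 receptor (Homo sapiens), read by resazurin assay, with stated times of 30 min and 2.5 days (on this read-out higher numbers stand for weaker inhibition and lower numbers for stronger inhibition), compound 1 gives 9800 nM. Compound 2 `COc1ccc(NC(=O)CSc2nnc(Cc3nn(C)c(=O)c4ccccc34)n2C)cc1` gives "not active" (no number reported) in this assay, and compound 3 `Cn1c(Cc2nn(C)c(=O)c3ccccc23)nnc1SCC(=O)Nc1ccc(F)cc1F` gives "not active" (no number reported) in this assay, so both stand without a value. Compound 4 `CCCCCCCCCCSc1nnc(Cc2nn(C)c(=O)c3ccccc23)n1C` keeps the shared core and the sulfur but differs from compound 1 in one place: heptyl in place of (2,4-dichlorophenyl)carbamoyl on a saturated chain carbon, three bonds along the chain from a sulfur. Among the compounds with values here, no pair of measured compounds shows a step of this kind, and the two entries without a number give no guidance on its size. The expected step of a 2.6-fold higher number from compound 1 to compound 4 (0.41 log units; beyond the scatter) in this assay is toward weaker inhibition, beyond the scatter. Compound 4 is estimated at 25000 nM, within 8000 nM to 80000 nM, with a fair chance of no number at all.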

Compound 4, half-maximal inhibitory concentration: 7600 nM
Compound 4: the middle estimate sits 3.3-fold (0.52 log units) above what was measured, and the stated range ends above it.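

In this assay the step of a 1.3-fold lower number from compound 1 to compound 4 (0.11 log units; within the scatter) puts heptyl level with (2,4-dichlorophenyl)carbamoyl on a saturated chain carbon, three bonds along the chain from a sulfur. In this pair, a measurable number therefore does not depend on the amide or the aromatic ring of the departing group. No measurement at hand explains this result.

From the compounds shown here alone, whether an amine, a carboxylic acid or a longer chain in this place would keep a number in this assay stays open.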